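A few compounds are considered here, and "the series" means these few. Any claim that something is new, unique, unknown or untested is made for them only; others in the source may bear on it.

Three of the four compounds in this set have been measured, and the fourth is still to be tested. Compound 1 `O=C(NO)c1ccc(/C=C/c2ccnc(-c3ccccc3O)c2)cc1`, compound 2 `Cc1ccc(-c2cc(/C=C/c3ccc(C(=O)NO)cc3)ccn2)c(F)c1` and compound 3 `Cc1ccc(-c2cncc(/C=C/c3ccc(C(=O)NO)cc3)c2)c(F)c1` have numbers; compound 4 `O=C(NO)c1ccc(/C=C/c2cncc(-c3ccccc3O)c2)cc1` does not yet.

In a functional assay on HCT-116 cells (Homo sapiens) for antiproliferative activity, read by CellTiter-Glo, with a stated time of 72 h (a lower number here means a stronger inhibitor, a higher number a weaker inhibitor), compound 2 gives 800 nM. Compound 1 gives 1450 nM in this assay. Between these two the only change is 2-hydroxyphenyl in place of 2-fluoro-4-methylphenyl on an aromatic carbon, and the step it made was a 1.8-fold higher number from compound 2 to compound 1 (0.26 log units; within the scatter), so the two numbers cannot be told apart with confidence.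

Compound 3 gives 2990 nM in this assay, the highest number of the three measured compounds. Compound 2 and compound 3 are built from the same atoms joined differently; the difference between the two cores is not broken down here.

Compound 4 is reached from compound 3 by the same kind of change that led from compound 2 to compound 1, namely (2-hydroxyphenyl in place of 2-fluoro-4-methylphenyl on an aromatic carbon). The surroundings of the place are not identical: from compound 2 to compound 1 the changed group sits next to the ring nitrogen, whereas from compound 3 to compound 4 it sits two atoms from the ring nitrogen. Since compound 3 starts from 2990 nM, the step is expected to be a 1.7-fold higher number from compound 3 to compound 4 (0.22 log units; within the scatter), resting on the earlier step of a 1.8-fold higher number from compound 2 to compound 1 (0.26 log units; within the scatter) from compound 2 to compound 1. Compound 4 is therefore estimated at 5000 nM, with a range from 2500 nM to 12000 nM.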

Compound 4, half-maximal inhibitory concentration: 4680 nM
The estimate for compound 4 lay 1.1-fold (0.03 log units) above the measured number; the range from low to high includes it.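

In this assay, putting 2-hydroxyphenyl in place of 2-fluoro-4-methylphenyl gave a 1.6-fold higher number from compound 3 to compound 4 (0.19 log units; within the scatter) and so, on this core as on the earlier one, the two groups cannot be told apart with confidence. Set side by side, the two steps agree, which means the change carried over from one core to the other with no detectable difference: the same change on two cores in this assay, a 1.8-fold higher number (0.26 log units; within the scatter) from compound 2 to compound 1 and a 1.6-fold higher number (0.19 log units; within the scatter) from compound 3 to compound 4, 1.2-fold (0.06 log units) apart, within the scatter of two such steps. Going by these compounds alone, this shows only that the swap left the number within the scatter on both cores, in one assay and across two pairs of compounds; it does not show that 2-hydroxyphenyl truly gives a higher number than 2-fluoro-4-methylphenyl, nor that the same small step would appear on a third core or in a different kind of test.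

The compounds shown carry only these two groups at this place on two cores, so it stays open whether a phenyl ring bearing an amine or a carboxylic acid would behave in the same way. On these data alone, it also stays open whether a longer chain in place of the aromatic group would produce a step beyond the scatter on either core.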